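The compounds below may be only part of what the source reports. "The series", "measured", "known", "first", "only" and "open" are said of these compounds alone.

Compound 1 `C#CCN(C)Cc1cccc(NC(=O)CCCC(=O)NO)c1` gives in a functional assay on DU-145 cells (Homo sapiens) for inhibition, read by MTT assay, with a stated time of 48 h (a lower number here means a stronger inhibitor of growth, a higher number a weaker inhibitor of growth), only the limit > 10000 nM.
Compound 2 `C#CCN(C)Cc1cccc(NC(=O)CCCCC(=O)NO)c1` gives in this assay 9750 nM.
Compound 3 `C#CCN(C)Cc1ccc(NC(=O)CCCC(=O)NO)cc1` gives in this assay only the limit > 10000 nM.

Compound 3 thus stands at a limit rather than a number, sharing the limit of > 10000 nM in this assay, at which 2 of the 3 values shown sit, with compound 1. The change to compound 4 `C#CCN(C)Cc1ccc(NC(=O)CCCCCCCCC(=O)NO)cc1` is 5-(hydroxycarbamoyl)pentyl in place of hydroxycarbamoyl on a saturated chain carbon, three bonds along the chain from a carbonyl carbon. Among the compounds with values here, the one measured step of related kind, an at least 1.0-fold lower number from compound 1 to compound 2 (0.01 log units; that floor lies within the scatter), put (hydroxycarbamoyl)methyl in place of hydroxycarbamoyl and stayed within the scatter. The change to compound 4 is much larger, so that step offers only a faint hint of direction. Compound 4 is therefore expected to give about 3000 nM, between 800 nM and 10000 nM. This expected step an at least 3.3-fold lower number from compound 3 to compound 4 (0.52 log units; beyond the scatter) would run toward a lower number, beyond the scatter.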

Compound 4, concentration for 50% growth inhibition: 2740 nM
Compound 4: middle estimate off by 1.1-fold (0.04 log units), on the high side, within the range that was stated.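

In this assay, 5-(hydroxycarbamoyl)pentyl in place of hydroxycarbamoyl gives an at least 3.6-fold lower number from compound 3 to compound 4 (0.56 log units; beyond the scatter). A change at this saturated chain carbon can therefore move the number beyond the scatter, which the (hydroxycarbamoyl)methyl change did not do. The true size of the step remains open, since compound 3 carries only a limit and not a number: the limit of > 10000 nM in this assay, at which 2 of the 4 values shown sit.

Going by these compounds, it remains open whether a longer chain would lower the number further, or whether a chain of intermediate length would already do so. On these data alone, what a carboxylic acid in place of the hydroxycarbamoyl would give also remains open.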